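This account rests on a few compounds, and the source may have more. Where it says the series, first, only, none or still open, it means among the compounds named here.

In a functional assay on NCI-H1792 cells (Homo sapiens) for cytotoxicity, read by resazurin assay, with a stated time of 72 h (a lower number here means a stronger inhibitor, a higher number a weaker inhibitor), compound 3, `COc1cc(/C=C/C(=O)OCc2c(-c3ccccc3)no[n+]2[O-])ccc1O`, gives 11100 nM, while compound 2, `O=C(/C=C/c1ccc(O)c(O)c1)OCc1c(-c2ccccc2)no[n+]1[O-]`, gives 3780 nM. These two differ in a single spot, (hydrogen in place of methyl on an oxygen on an aromatic ring), and the step is a 2.9-fold lower number from compound 3 to compound 2 (0.47 log units; beyond the scatter). Compound 1, `COc1cc(/C=C/C(=O)OCCCO[N+](=O)[O-])ccc1OCCCO[N+](=O)[O-]`, is built on another core; how its core differs from that of compound 3 is not broken down here. In this assay compound 1 gives only a limit, > 50000 nM, which is the limit of > 50000 nM in this assay, at which 1 of the 3 values shown sits. Among the measured compounds shown here, compound 4, `O=C(/C=C/c1ccc(OCCCO[N+](=O)[O-])c(O)c1)OCCCO[N+](=O)[O-]`, has not been measured; it differs from compound 1 by hydrogen in place of methyl on an oxygen on an aromatic ring, the same change as the one between compound 3 and compound 2, made at a place described in the same words. For the measured compounds named here, the step expected here is an at least 1.2-fold lower number from compound 1 to compound 4 (0.09 log units; that floor lies within the scatter), and this rests on the measured pair because a 2.9-fold lower number from compound 3 to compound 2 (0.47 log units; beyond the scatter) is the only record of this change. Compound 1 sits at a limit, so the starting point is itself uncertain. Compound 4 is therefore expected to give around 40000 nM, somewhere between 12000 nM and 150000 nM, and there is a real chance that only a limit is reported again.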

Compound 4, half-maximal inhibitory concentration: 6610 nM
The estimate for compound 4 lay 6.1-fold (0.78 log units) above the measured number; measured number outside the range, below it.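

In this assay, replacing methoxy with hydroxy gives a lower number on the core of compound 1 as well, and the new step is an at least 7.5-fold lower number from compound 1 to compound 4 (0.87 log units; beyond the scatter). Compound 1 gives > 50000 nM, which is a limit of the assay and not a number, so this step has a floor but no known upper end. The change thus points the same way on both cores, which shows that its direction carries over here, but it does not show whether its size carries over: the same change on two cores in this assay, a 2.9-fold lower number (0.47 log units; beyond the scatter) from compound 3 to compound 2 and an at least 7.5-fold lower number (0.87 log units; beyond the scatter) from compound 1 to compound 4; the limit leaves it open whether they differ

The compounds shown leave open how a longer chain, such as an ethyl group on that same oxygen, or an amine in place of the hydroxy group would read in this assay. Among the compounds shown here, with only two cores to compare, they also leave open whether the change would lower the number on any further core.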